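Oral exposure across side chains on a shared core

This account rests on a few compounds, and the source may have more. Where it says the series, first, only, none or still open, it means among the compounds named here.

Measured so far in an ADME assay on the whole organism (strain FVB) for pharmacokinetics, with Mus musculus as the target, read by LC-MS, at a dose of 30 mg/kg by the oral route; on this read-out lower numbers stand for lower exposure and higher numbers for higher exposure at the dose given:
- compound 1 `CC(C)(O)CN1CCC(Oc2ccc([C@H]3CC[C@]4(CC3)OOC3(O4)C4CC5CC(C4)CC3C5)cc2)CC1` gives 14200 ng.h/mL
- compound 2 `NCCCCOc1ccc([C@H]2CC[C@]3(CC2)OOC2(O3)C3CC4CC(C3)CC2C4)cc1` gives 4700 ng.h/mL

Compound 2 at 4700 ng.h/mL is the lower of the two numbers. Compound 3 `O[C@H]1CC[C@H](NCCCOc2ccc([C@H]3CC[C@]4(CC3)OOC3(O4)C4CC5CC(C4)CC3C5)cc2)CC1` keeps the shared core and carries (4-hydroxycyclohexyl)amino in place of aminomethyl on a saturated chain carbon, three bonds along the chain from an oxygen on an aromatic ring, which counts as (4-hydroxycyclohexyl)amino in place of aminomethyl on a saturated chain carbon, three bonds along the chain from an oxygen on an aromatic ring in full. Among the measured compounds shown here, one measured step bears on this, a 3.0-fold lower number from compound 1 to compound 2 (0.48 log units; beyond the scatter), with 4-aminobutyl in place of 1-(2-hydroxy-2-methylpropyl)piperidin-4-yl. The side chain of compound 3 again holds a ring and a hydroxy group, as that of compound 1 does, so a modest rise is expected, smaller than that measured step. This rests on a single step. The expected step is a 1.8-fold higher number from compound 2 to compound 3 (0.26 log units; within the scatter) in this assay on this reasoning. Compound 3 is estimated at 8500 ng.h/mL with an expected range from 3000 ng.h/mL to 24000 ng.h/mL as its bounds.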

Compound 3, area under the concentration-time curve: 6570 ng.h/mL
Beside the measured number, compound 3's estimate is 1.3-fold (0.11 log units) above it, within the range that was stated.
By their numbers in this assay, from the lowest: compounds 2 and 3 (each within the scatter of the next); then compound 1.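

In this assay, (4-hydroxycyclohexyl)amino in place of aminomethyl on a saturated chain carbon, three bonds along the chain from an oxygen on an aromatic ring, gives a 1.4-fold higher number from compound 2 to compound 3 (0.15 log units; within the scatter), so this place accepts the added ring and hydroxy group without a change that can be told from the scatter. A ring and a hydroxy group in the side chain do not by themselves match compound 1, since 3-((4-hydroxycyclohexyl)amino)propyl in place of 1-(2-hydroxy-2-methylpropyl)piperidin-4-yl on an oxygen on an aromatic ring gives a 2.2-fold lower number from compound 1 to compound 3 (0.33 log units; beyond the scatter). No measurement at hand accounts for either step.

Still open, going by these compounds, is what a plain cyclohexylamino group or a morpholine would give at this place. That would separate any contribution of the hydroxy group from that of the ring.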